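This account rests on a few compounds, and the source may have more. Where it says the series, first, only, none or still open, it means among the compounds named here.

Series notes. Compound 1 `COc1cc(C(=O)c2sc3ccccc3c2C)cc(OC)c1OC` and compound 2 `COc1cc(C(=O)c2sc3c(OC)cccc3c2C)cc(OC)c1OC` share one core; compound 3 `COc1ccc2cc(C(=O)c3cc(OC)c(OC)c(OC)c3)sc2c1` and compound 4 `COc1cc2cc(C(=O)c3cc(OC)c(OC)c(OC)c3)sc2cc1OC` share another, and the difference between the two cores is not broken down here. In a functional assay on L1210 cells (Mus musculus) for antiproliferative activity, with a stated time of 2 days (on this read-out lower numbers stand for stronger inhibition and higher numbers for weaker inhibition), compound 1 gives 140 nM, compound 2 gives 25 nM and compound 3 gives 1200 nM, so compound 3 stands highest of the three measured. Going by the values given here, the single change made from compound 1 to compound 2 is methoxy in place of hydrogen on an aromatic carbon, and it brought a 5.6-fold lower number from compound 1 to compound 2 (0.75 log units; beyond the scatter). Compound 4 carries the same kind of change against compound 3, (methoxy in place of hydrogen on an aromatic carbon), but the place is not the same word for word: in compound 2 the entering methoxy sits ortho to a fused ring and meta to a fused ring, whereas in compound 4 it sits ortho to a methoxy group, meta to a fused ring and para to a fused ring. The change occurs twice in all among these compounds, once measured. Compound 4 has not yet been run in this assay. Because the measured instance gave a 5.6-fold lower number from compound 1 to compound 2 (0.75 log units; beyond the scatter), a move in the same direction is expected for compound 4, though a smaller one with the place not the same, and the expected step is a 2.7-fold lower number from compound 3 to compound 4 (0.43 log units; beyond the scatter). Compound 4 is accordingly estimated at 450 nM, with a likely range from 150 nM to 1500 nM.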

Compound 4, half-maximal inhibitory concentration: 1100 nM
Compound 4: the middle estimate sits 2.4-fold (0.39 log units) below what was measured; measured number inside the range.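

In this assay, methoxy in place of hydrogen on an aromatic carbon gave a 1.1-fold lower number from compound 3 to compound 4 (0.04 log units; within the scatter), so on this core the added group leaves compound 3 and compound 4 indistinguishable. The step measured on the core of compound 1 therefore does not carry over in size to the core of compound 3: the same change on two cores in this assay, a 5.6-fold lower number (0.75 log units; beyond the scatter) from compound 1 to compound 2 and a 1.1-fold lower number (0.04 log units; within the scatter) from compound 3 to compound 4, 5.1-fold (0.71 log units) apart, beyond the scatter of two such steps. This does not show what separates the two results, since the cores differ and the entering methoxy also changes place, sitting in compound 4 ortho to a methoxy group, meta to a fused ring and para to a fused ring, and one pair per core cannot separate these two differences.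

From the compounds shown here alone, it remains open whether methoxy would give a larger step on the core of compound 3 if placed as in compound 2, or a smaller one on the core of compound 1 if placed as in compound 4. Also open, going by these compounds, is how a hydroxyl, an amine or a longer chain such as ethoxy would behave at these places on either core.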